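This account rests on a few compounds, and the source may have more. Where it says the series, first, only, none or still open, it means among the compounds named here.

Measured in an ADME assay on Vero cells (Chlorocebus sabaeus) for cytotoxicity, with a stated time of 72 h; a lower number here means a stronger inhibitor, a higher number a weaker inhibitor:

- compound 1 `O=[N+]([O-])c1cn2c(n1)OC[C@@H](OCc1ccc(-c3ccc(F)cc3)s1)C2` gives > 128000 nM, which is a limit of this assay.
- compound 2 `COc1ccc(-c2ccc(CO[C@@H]3COc4nc([N+](=O)[O-])cn4C3)s2)cc1F` gives > 128000 nM, which is a limit of this assay.
- compound 3 `Cn1c(CO[C@@H]2COc3nc([N+](=O)[O-])cn3C2)cnc1-c1ccc(F)cc1` gives > 128000 nM, which is a limit of this assay.

Compound 1 and compound 2 differ by 3-fluoro-4-methoxyphenyl in place of 4-fluorophenyl on an aromatic carbon. The step that the two limits leave unreadable from compound 1 to compound 2 cannot be sized, since both values sit at the limit of > 128000 nM in this assay, at which 3 of the 3 values shown sit.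

Compound 4 `COc1ccc(-c2ncc(CO[C@@H]3COc4nc([N+](=O)[O-])cn4C3)n2C)cc1F` has not yet been measured in this assay. It differs from compound 3 by 3-fluoro-4-methoxyphenyl in place of 4-fluorophenyl on an aromatic carbon. This is the same kind of change as from compound 1 to compound 2, but the surroundings differ: in compound 1 the group sits on an aromatic carbon of a five-membered aromatic ring with 1 sulfur, next to the ring sulfur; in compound 3 it sits on an aromatic carbon of a five-membered aromatic ring with 2 nitrogen, between two ring nitrogen atoms, next to the ring atom that bears a methyl group. The difference between the core of compound 1 and the core of compound 3 is not broken down here.

The step from compound 3 to compound 4 is expected to be a number no higher from compound 3 to compound 4 (the limit leaves the size open) in this assay, because the limit of > 128000 nM in this assay, at which 3 of the 3 values shown sit, is where every value shown so far sits. Compound 4 is therefore estimated at 128000 nM, between 64000 nM and 256000 nM, most likely again reported only as a limit.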

Compound 4, half-maximal inhibitory concentration: > 128000 nM
Compound 4: no number, only a limit; the forecaster's own chance of this, stated with the estimate: 90%; the middle value sits exactly at the limit.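

No step can be read from compound 3 to compound 4, since both values are limits and not numbers: the limit of > 128000 nM in this assay, at which 4 of the 4 values shown sit.

The compounds shown leave open whether 3-fluoro-4-methoxyphenyl in place of 4-fluorophenyl changes the read-out of this assay at all, on either core, and how the four compounds compare with one another.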